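The source may report more compounds than this note shows. Statements on the series, on what has been measured and on what is new or still open speak of the compounds shown alone.

Of the three measured compounds, compound 3 `CN(C)CCn1cnnc1-c1cc(Oc2ccc(NC(=O)N/N=C/c3cc(Br)c(O)c(Br)c3)cc2F)ccn1` stands highest in a functional assay on HT-29 cells (Homo sapiens) for cytotoxicity, read by MTT assay, with a stated time of 72 h (on this read-out lower numbers stand for stronger inhibition and higher numbers for weaker inhibition), giving 2670 nM. Compound 1 `CN(C)CCn1cnnc1-c1cc(Oc2ccc(NC(=O)N/N=C/c3ccc(O)c(Br)c3)cc2F)ccn1` gives 450 nM, and compound 2 `CN(C)CCn1cnnc1-c1cc(Oc2ccc(NC(=O)N/N=C/c3ccccc3O[N+](=O)[O-])cc2F)ccn1` gives 950 nM. Compound 4 `CN(C)CCn1cnnc1-c1cc(Oc2ccc(NC(=O)N/N=C/c3ccc(O)cc3)cc2F)ccn1` differs from compound 3 in one place: 4-hydroxyphenyl in place of 3,5-dibromo-4-hydroxyphenyl on a carbon with a double bond to nitrogen. The measured step that bears on this change runs the other way: a 5.9-fold higher number from compound 1 to compound 3 (0.77 log units; beyond the scatter), a bromine in place of hydrogen raising the number. Removing both bromines from compound 3 reverses and extends that move. The other step, a 2.8-fold higher number from compound 2 to compound 3 (0.45 log units; beyond the scatter), exchanges the whole ring and says less about this change. Within the data shown here, no measured compound carries the bare 4-hydroxyphenyl, so whether the second bromine costs as much as the first is unknown, and the estimate is kept wide. Compound 4 is therefore expected to give a clearly lower number, with an estimated step of a 4.5-fold lower number from compound 3 to compound 4 (0.65 log units; beyond the scatter). The estimate for compound 4 is 600 nM, within an expected range from 150 nM to 2400 nM.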

Compound 4, half-maximal inhibitory concentration: 1920 nM
Compound 4: middle estimate off by 3.2-fold (0.51 log units), on the low side; the measured number falls inside the stated range.
By their numbers in this assay, from the lowest: compound 1; then compound 2; then compounds 4 and 3 (each within the scatter of the next).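

In this assay, the two bromo groups of the 3,5-dibromo-4-hydroxyphenyl can be removed with no readable effect, giving a 1.4-fold lower number from compound 3 to compound 4 (0.14 log units; within the scatter). Yet hydrogen in place of bromo on the 3-bromo-4-hydroxyphenyl of compound 1 gives a 4.3-fold higher number from compound 1 to compound 4 (0.63 log units; beyond the scatter), so the number does not climb steadily with the count of bromo groups: the 3-bromo-4-hydroxyphenyl stands apart from both the bromine-free group and the dibromo group. The 4-hydroxyphenyl also offers no gain over the 2-(nitrooxy)phenyl, with a 2.0-fold higher number from compound 2 to compound 4 (0.31 log units; beyond the scatter).

No evidence is at hand on why the 3-bromo-4-hydroxyphenyl stands apart. Going by these compounds, whether a chloro or a methoxy group in place of its bromo would keep the low number of compound 1 also remains open.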